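Working notes: the step from compound 3 to compound 4

The compounds below may be only part of what the source reports. "The series", "measured", "known", "first", "only" and "open" are said of these compounds alone.

In a functional assay on HepG2 cells (Homo sapiens), read by MTT assay, with a stated time of 48 h (a higher number here means a weaker inhibitor, a lower number a stronger inhibitor), compound 1 `CCOC(=O)CN(C)C(=O)c1ccc(C(CC)(CC)c2ccc(OCC(O)C(C)(C)C)c(C)c2)n1CC` gives > 50000 nM as a limit of the assay and not a number. Compound 2 `CCN(CC)CCNC(=O)c1ccc(C(CC)(CC)c2ccc(OCC(O)C(C)(C)C)c(C)c2)n1CC` gives 490 nM and compound 3 `CCn1c(C(=O)N(C)CC(=O)O)ccc1C(CC)(CC)c1ccc(OCC(=O)C(C)(C)C)c(C)c1` gives 25200 nM as the higher of the two actual numbers. Compound 4 `CCn1c(C(=O)N(C)CC(=O)O)ccc1C(CC)(CC)c1ccc(OCC(O)C(C)(C)C)c(C)c1` is still unmeasured and differs from compound 3 by 1-hydroxy-2,2-dimethylpropyl in place of (tert-butyl)carbonyl on a saturated chain carbon bound to an oxygen on an aromatic ring with nothing else changed. Within the data shown here, the only measured step is an at least 100-fold lower number from compound 1 to compound 2 (2.00 log units; beyond the scatter) and it is large, but it sits on a carbonyl carbon, at another place, and gives no size for this change. Among the measured compounds shown here, compound 1 and compound 2 both carry the 2-hydroxy-3,3-dimethylbutoxy group, yet no measured pair isolates it. The anchor is therefore compound 3 at 25200 nM with no step beyond the scatter expected in this assay for this change. The expected move is a 1.3-fold lower number from compound 3 to compound 4 (0.10 log units; within the scatter) and it stays within the scatter, with wide uncertainty. For compound 4 the estimated value is 20000 nM with an expected range from 7000 nM to 50000 nM as a working figure.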

Compound 4, half-maximal inhibitory concentration: 17100 nM
The estimate for compound 4 lay 1.2-fold (0.07 log units) above the measured number; low and high end bracket the measured number.
By their numbers in this assay, from the lowest: compound 2; then compounds 4 and 3 (each within the scatter of the next). At a limit, above all of these: compound 1.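

At the saturated chain carbon bound to an oxygen on an aromatic ring, 1-hydroxy-2,2-dimethylpropyl in place of (tert-butyl)carbonyl gives in this assay a 1.5-fold lower number from compound 3 to compound 4 (0.17 log units; within the scatter), the first size for this change, and it stays small beside the change on the carbonyl carbon. With 2-hydroxy-3,3-dimethylbutoxy held constant, (carboxymethyl)(methyl)amino in place of (2-(diethylamino)ethyl)amino gives a 35-fold higher number from compound 2 to compound 4 (1.54 log units; beyond the scatter). Compound 1 stands at a limit of the assay, so hydrogen in place of ethyl on an oxygen next to a carbonyl group gives only a bound, an at least 2.9-fold lower number from compound 1 to compound 4 (0.46 log units; beyond the scatter), in a set with one such value: the limit of > 50000 nM in this assay, at which 1 of the 4 values shown sits.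

On these data alone, the change from (tert-butyl)carbonyl to 1-hydroxy-2,2-dimethylpropyl is sized only with (carboxymethyl)(methyl)amino on the carbonyl carbon, so its size with (2-(diethylamino)ethyl)amino remains open. As far as these compounds go, a methyl ether of the hydroxy group or a primary amine at the same carbon also remains open.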